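Working notes on microsomal stability in a sulfone series

The compounds below may be only part of what the source reports. "The series", "measured", "known", "first", "only" and "open" are said of these compounds alone.

Measured so far:
- compound 1 `CCCCc1nc(=O)c(S(=O)(=O)c2ccc(-c3ccc(F)cc3)cc2)c(O)n1-c1c(OC)cccc1OC`: in an ADME assay on microsomes from liver (Homo sapiens) for metabolic stability, using NADPH, with a stated time of 10 min (a lower number here means that less of the compound is left, a higher number that more of the compound is left), compound 1 gives 100%
- compound 2 `CCCCc1[nH]c(=O)c(S(=O)(=O)c2ccc(-c3ccncc3C)cc2)c(O)c1-c1c(OC)cccc1OC`: in this assay compound 2 gives 80%

Within the data shown here, of the two numbers known, compound 2 stands lowest; its nearest neighbour is compound 1, which lies higher by a margin beyond the usual scatter. Among the measured compounds shown here, compounds 1 and 2 differ in more than one place, so no single step between measured compounds is available.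

Compound 3 `CCCCc1[nH]c(=O)c(S(=O)(=O)c2ccc(-n3cc(Cl)ccc3=O)cc2)c(O)c1-c1c(OC)cccc1OC` differs from compound 2 by a group of 8 heavy atoms (5 carbon, 1 nitrogen, 1 oxygen, 1 chlorine; one six-membered aromatic ring with 1 hetero atom) in place of a group of 7 heavy atoms (6 carbon, 1 nitrogen; one six-membered aromatic ring with 1 hetero atom), on an aromatic carbon.

For the measured compounds named here, with no measured pair informing this change, the step from compound 2 to compound 3 is expected to be a number 2 percentage points lower from compound 2 to compound 3 (within the scatter), no clear direction beyond the scatter. Compound 3 is expected to give 78%, estimated between 55% and 100%.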

Compound 3, percent of the compound remaining: 97%
Beside the measured number, compound 3's estimate is 19 percentage points below it; the range from low to high includes it.
By their numbers in this assay, from the lowest: compound 2; then compounds 3 and 1 (each within the scatter of the next).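

In this assay, replacing the 3-methylpyridin-4-yl group on this aromatic carbon, para to a large group, with the chlorine-bearing ring and its carbonyl gives a number 17 percentage points higher from compound 2 to compound 3 (beyond the scatter) on the shared core. Among these compounds, this is the first single-place comparison, and it shows that this position accepts a change of ring with no loss of the compound remaining. No measurement at hand bears on the origin of this step.

On these data alone, whether the chlorine or the carbonyl of the entering ring carries the step remains open, as does the result for the unsubstituted ring. Also open, as far as these compounds go, is how a morpholine or a carboxylic acid on this aromatic carbon would behave in this assay, and a single step sets no trend for this position.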